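The source may report more compounds than this note shows. Statements on the series, on what has been measured and on what is new or still open speak of the compounds shown alone.

In an ADME assay on L02 cells (Homo sapiens) for inhibition, read by CCK-8 assay, with a stated time of 48 h (a lower number here means a stronger inhibitor of growth, a higher number a weaker inhibitor of growth), compound 1 `Cc1ccc(CNc2nc(Nc3ccc(N4CCN(C)CC4)cn3)ncc2Cl)cc1` gives > 100000 nM, which is a limit of the assay and not a number. Among the compounds with values here, compound 2 `CCc1ccc(Nc2nc(Nc3ccc(N4CCN(C)CC4)cn3)ncc2Cl)cc1` gives 12100 nM, the only true number so far. Compound 3 `CC(C)c1ccc(Nc2nc(Nc3ccc(N4CCN(C)CC4)cn3)ncc2Cl)cc1` changes compound 2 by one small edit, 4-ethylphenyl to 4-isopropylphenyl: methyl in place of hydrogen on a saturated chain carbon bound to an aromatic carbon and a saturated chain carbon. Within the data shown here, the one measured step touching this group is an at least 8.2-fold lower number from compound 1 to compound 2 (0.91 log units; beyond the scatter), but it is a different and larger swap, and it rests on (the limit of > 100000 nM in this assay, at which 1 of the 2 values shown sits). It offers little guidance, so no change beyond the scatter is expected, and the expected step is a 1.1-fold lower number from compound 2 to compound 3 (0.04 log units; within the scatter). The estimate for compound 3 is 11000 nM, with an expected range of 4500 nM to 30000 nM.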

Compound 3, concentration for 50% growth inhibition: 13700 nM
Compound 3: the middle estimate sits 1.2-fold (0.10 log units) below what was measured; measured number inside the range.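

In this assay, methyl on this saturated chain carbon gives a 1.1-fold higher number from compound 2 to compound 3 (0.05 log units; within the scatter), so going from ethyl to isopropyl brings no change that stands out from the scatter. The aniline-type link with a 4-alkylphenyl group thus holds its gap to the 4-methylbenzyl compound with a second group, at an at least 7.2-fold lower number from compound 1 to compound 3 (0.86 log units; beyond the scatter). That step gives only a minimum size, since compound 1 sits at a limit of the assay and not a number: the limit of > 100000 nM in this assay, at which 1 of the 3 values shown sits.

Still open, on these data alone, is whether a tert-butyl group, a longer chain or an amine in place of the isopropyl would move the number.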